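Thioester to Oxazole on a Dihydropyrimidinone Core

The source may report more compounds than this note shows. Statements on the series, on what has been measured and on what is new or still open speak of the compounds shown alone.

Measured so far:
Compound 1 `CCSC(=O)C1=C(C)NC(=O)NC1c1cccs1` gives 1% in an assay on membranes from HeLa cells for displacement of a labelled ligand from adenosine receptor A3 (Homo sapiens), read by scintillation counting, with a stated time of 180 min, tested at 1 uM; a higher number here means more inhibition at the concentration tested (going by the name of the read-out), a lower number less inhibition.
Compound 2 `CC1=C(C(=O)SC(C)C)C(c2cccs2)NC(=O)N1` gives 1% in this assay.

Compound 2 stands level with compound 1; the step of no change at the digits printed from compound 1 to compound 2 (within the scatter) shows that adding the methyl changed nothing beyond the scatter. Compound 3 `CC1=C(c2ncc(C)o2)C(c2cccs2)NC(=O)N1` differs from compound 2 by 5-methyl-1,3-oxazol-2-yl in place of (isopropylsulfanyl)carbonyl on a double-bonded ring carbon. Going by the values given here, no measured step touches this position or this kind of exchange, so the only guide is that the two measured compounds sit at the bottom of the scale. The expected step of a number 3 percentage points higher from compound 2 to compound 3 (within the scatter) is therefore none beyond the scatter. Compound 3 is estimated at 4%, within a range from 0% to 20%.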

Compound 3, a percentage reported as inhibition, at one concentration (the size of the read-out at that concentration, not a potency): 1%
The estimate for compound 3 lay 3 percentage points above the measured number; measured number inside the range.
By their numbers in this assay, from the lowest: compounds 1, 2 and 3 (each within the scatter of the next).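

Swapping either sulfur-bearing carbonyl group for 5-methyl-1,3-oxazol-2-yl on the double-bonded ring carbon leaves the reading in this assay flat, with no change at the digits printed from compound 2 to compound 3 (within the scatter) and also no change at the digits printed from compound 1 to compound 3 (within the scatter). So this position accepts an aromatic five-membered ring in place of an open chain group without any visible gain or loss, although all three readings lie so close to the bottom of the scale that a loss would be hard to see. Nothing available explains this result.

As far as these compounds go, whether an amine, a carboxylic acid or a longer chain on this carbon would raise the reading stays open. So does whether any change here can lift the shared core off the bottom of the scale.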